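Replacing the nitro aryl with a fluorophenyl: expected recovery

The compounds below may be only part of what the source reports. "The series", "measured", "known", "first", "only" and "open" are said of these compounds alone.

Three measured compounds share one core and differ only in the aryl group on the amine nitrogen. Compound 1 `N#Cc1c(Nc2cccc(C(F)(F)F)c2)nc(SCc2cn(Cc3ccccc3Cl)nn2)nc1-c1ccccc1` gives 32000 nM in a functional assay on ECa-109 cells (Homo sapiens) for inhibition, read by MTT assay, with a stated time of 72 h; a higher number here means a weaker inhibitor, a lower number a stronger inhibitor. Compound 2 `N#Cc1c(Nc2cccc(Cl)c2)nc(SCc2cn(Cc3ccccc3Cl)nn2)nc1-c1ccccc1` gives 24400 nM in this assay. Compound 3 `N#Cc1c(Nc2cccc([N+](=O)[O-])c2)nc(SCc2cn(Cc3ccccc3Cl)nn2)nc1-c1ccccc1` gives only > 64000 nM in this assay, which is a limit of the assay and not a number (the limit of > 64000 nM in this assay, at which 1 of the 3 values shown sits). Compound 3 thus stands at the top of the shown values, with an at least 2.6-fold higher number from compound 2 to compound 3 (0.41 log units; beyond the scatter) and an at least 2.0-fold higher number from compound 1 to compound 3 (0.30 log units; that floor lies within the scatter) both recording a rise as nitro enters.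

Compound 4 `N#Cc1c(Nc2ccc(F)cc2)nc(SCc2cn(Cc3ccccc3Cl)nn2)nc1-c1ccccc1` carries the change (4-fluorophenyl in place of 3-nitrophenyl on a nitrogen on an aromatic ring). Within the data shown here, no measured step matches this exact exchange, yet it removes the nitro group, and the steps of an at least 2.0-fold higher number from compound 1 to compound 3 (0.30 log units; that floor lies within the scatter) and an at least 2.6-fold higher number from compound 2 to compound 3 (0.41 log units; beyond the scatter) show that the entry of nitro raised the number, so its departure is expected to lower it. Compound 4 is therefore expected to come back to roughly the level of compounds 1 and 2, a step of an at least 2.1-fold lower number from compound 3 to compound 4 (0.32 log units; beyond the scatter). Compound 4 is estimated at 30000 nM, within a range from 12000 nM to 90000 nM, the uncertainty widened because compound 3 itself gave only > 64000 nM.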

Compound 4, half-maximal inhibitory concentration: 25800 nM
For compound 4 the middle estimate is 1.2-fold (0.07 log units) above the measured one; the measured number falls inside the stated range.
By their numbers in this assay, from the lowest: compounds 2, 4 and 1 (each within the scatter of the next). At a limit, above all of these: compound 3.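

Removing the nitro group does bring the number down, with an at least 2.4-fold lower number from compound 3 to compound 4 (0.39 log units; beyond the scatter) in this assay. Compound 3 still marks the top of the series only as a limit of the assay and not as a number: the limit of > 64000 nM in this assay, at which 1 of the 4 values shown sits. New here is that the aryl group on this nitrogen tolerates a change of both substituent and its place on the ring without a readable shift, with a 1.1-fold higher number from compound 2 to compound 4 (0.02 log units; within the scatter) and a 1.2-fold lower number from compound 1 to compound 4 (0.09 log units; within the scatter), so the 4-fluorophenyl, 3-chlorophenyl and 3-(trifluoromethyl)phenyl compounds cannot be told apart.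

All three of these values remain high, so the compounds shown leave open whether any group on this aryl ring can lower the number much further. An amine or a carboxylic acid on the ring, or a plain alkyl chain in place of the aryl group, remains an open case.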